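This account rests on a few compounds, and the source may have more. Where it says the series, first, only, none or still open, it means among the compounds named here.

Measured compounds:
Compound 1, `N#Cc1cnc(NCc2cnccc2C(F)(F)F)cc1NC[C@H]1CC[C@@H](O)CC1`, in an assay on isolated protein for inhibition of protein kinase C theta type (Homo sapiens), read by TR-FRET, with a stated time of 2 h (on this read-out higher numbers stand for weaker inhibition and lower numbers for stronger inhibition), compound 1 gives 58 nM.
Compound 2, `CC1(C)[C@H](O)C[C@H]1Nc1nc(NCc2cnccc2C(F)(F)F)ncc1C#N`, in this assay compound 2 gives 130 nM.
Compound 3, `CC1(C)[C@H](O)C[C@@H]1Nc1nc(NCc2cnccc2C(F)(F)F)ncc1C#N`, in this assay compound 3 gives 300 nM.

Compound 1 stands lowest of the three numbers in this assay, and both of its gaps to the others lie beyond the scatter, so it is the strongest inhibitor of the set. Compound 2 and compound 3 share the same atoms and bonds and differ only in configuration; the step of a 2.3-fold higher number from compound 2 to compound 3 (0.36 log units; beyond the scatter) shows that the drawn configuration at the saturated ring carbon matters to a modest degree, and this follows from the fact that compounds 2 and 3 differ only in the configuration as drawn. Within the data shown here, no single-place step connects compound 1 to compound 2 or compound 3; their values simply show that the cyclobutyl-bearing analogues on the other core sit higher than compound 1.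

Compound 4, `CC1(C)[C@@H](C(N)=O)C[C@H]1Nc1cc(NCc2cnccc2C(F)(F)F)ncc1C#N`, has not yet been measured. It differs from compound 1 by 3-carbamoyl-2,2-dimethylcyclobutyl in place of (4-hydroxycyclohexyl)methyl on a nitrogen on an aromatic ring. Among the measured compounds shown here, the only measured step that touches this part of the molecule is the configurational one from compound 2 to compound 3, which was modest. Nothing measured speaks to the carboxamide or to the change of ring size on the core of compound 1, so the expectation is uncertain. Compound 4 is expected to give 100 nM (range 30 nM to 400 nM) in this assay, a step of a 1.7-fold higher number from compound 1 to compound 4 (0.24 log units; within the scatter) toward a somewhat higher number, which may not exceed the scatter.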

Compound 4, half-maximal inhibitory concentration: 1.4 nM
Compound 4: the middle estimate sits 71-fold (1.85 log units) above what was measured; measured number below the stated range.
By their numbers in this assay, from the lowest: compound 4; then compound 1; then compound 2; then compound 3.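

In this assay, the group on a nitrogen on an aromatic ring proves to be a powerful point of change on the core of compound 1: 3-carbamoyl-2,2-dimethylcyclobutyl in place of (4-hydroxycyclohexyl)methyl gives a 41-fold lower number from compound 1 to compound 4 (1.62 log units; beyond the scatter). The earlier compounds shown here offered only a modest configurational step on another core, so they gave no sign that a change at this position could move the number this far, and the new step arrives with the count of hydrogen-bond donors and acceptors unchanged between the two groups. Nothing measured here explains why this exchange has so large an effect.

The exchange alters the ring, the carbon chain to the nitrogen and the polar group together, so the compounds shown leave open how much of the step belongs to the carbamoyl group, the four-membered ring or the two methyl groups. They also leave open how the number would respond on this core to the opposite configuration of the cyclobutyl ring, or to a carboxylic acid or a methyl ester in place of the carbamoyl group.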